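The compounds below may be only part of what the source reports. "The series", "measured", "known", "first", "only" and "open" are said of these compounds alone.

In a functional assay on HepG2 cells (Homo sapiens) for antiproliferative activity, read by MTT assay (on this read-out lower numbers stand for stronger inhibition and higher numbers for weaker inhibition), compound 1 `COc1ccc(-n2cc(COc3ccc(/C=C/C(=O)c4ccc5c(c4O)CCC(C)(C)O5)cc3)nn2)c([N+](=O)[O-])c1` gives 120000 nM, and compound 2 `CCCCCCCCn1cc(COc2ccc(/C=C/C(=O)c3cc4c(cc3O)OC(C)(C)CC4)cc2)nn1` gives 127000 nM, so the two numbers sit within the scatter of each other and neither can be set apart. Compound 3 `CCCCCn1cc(COc2ccc(/C=C/C(=O)c3ccc4c(c3O)CCC(C)(C)O4)cc2)nn1` differs from compound 1 by pentyl in place of 4-methoxy-2-nitrophenyl on an aromatic nitrogen. Among the measured compounds shown here, no measured pair shows this change, but compound 2 carries an octyl on the same aromatic nitrogen and its value of 127000 nM stays close to compound 1, so the expected step of a 1.1-fold lower number from compound 1 to compound 3 (0.04 log units; within the scatter) lies within the scatter, in no particular direction. Compound 3 is therefore estimated at 110000 nM, between 50000 nM and 250000 nM.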

Compound 3, half-maximal inhibitory concentration: 9820 nM
Estimate against measurement, compound 3: 11-fold (1.05 log units) above; measured number below the stated range.
By their numbers in this assay, from the lowest: compound 3; then compounds 1 and 2 (each within the scatter of the next).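

In this assay the change to pentyl from 4-methoxy-2-nitrophenyl on the aromatic nitrogen gives a 12-fold lower number from compound 1 to compound 3 (1.09 log units; beyond the scatter) and so shows that the group at this position can shift the number well beyond the scatter, which the earlier pair, differing in more than one place, could not show. Nothing available explains this step. The compounds shown leave open whether a plain phenyl on this nitrogen would keep the higher number of compound 1. They also leave open how a butyl chain or a chain ending in an amine would read on the core of compound 3.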